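The compounds below may be only part of what the source reports. "The series", "measured", "known", "first", "only" and "open" are said of these compounds alone.

Measured compounds:
compound 1, `Cc1nc(-c2ccc(F)cc2)c(C(=O)N2CCN(c3cccc(Cl)c3)CC2)o1`, 40.1 nM in a functional assay on HL-60 cells (Homo sapiens) for inhibition, read by MTT assay, with a stated time of 72 h; a higher number here means a weaker inhibitor, a lower number a stronger inhibitor
compound 2, `COc1cccc(N2CCN(C(=O)c3oc(C)nc3-c3ccc(F)cc3)CC2)c1`, 112 nM
compound 3, `CCc1nc(-c2cccc(F)c2)c(C(=O)N2CCN(c3cccc(Cl)c3)CC2)o1`, 317 nM

Compound 4, `CCc1nc(-c2cccc(F)c2)c(C(=O)N2CCN(c3cccc(OC)c3)CC2)o1`, has not yet been measured in this assay.

Compound 2 differs from compound 1 by methoxy in place of chloro on an aromatic carbon, and that change gave a 2.8-fold higher number from compound 1 to compound 2 (0.45 log units; beyond the scatter). Compound 4 differs from compound 3 by methoxy in place of chloro on an aromatic carbon, on the same kind of ring and at the same kind of place as the earlier change, so it is the same change, made on a second core. Among the measured compounds shown here, how the core of compound 3 differs from the core of compound 1 is not broken down here; the two values show only that compound 3 gives a higher number than compound 1 in this assay.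

For the measured compounds named here, the one earlier example of this change weakened inhibition by a modest amount. Going by the values given here, the expectation for compound 4 is therefore a step of similar size, a 2.7-fold higher number from compound 3 to compound 4 (0.43 log units; beyond the scatter), which rests on the single precedent a 2.8-fold higher number from compound 1 to compound 2 (0.45 log units; beyond the scatter) and carries the uncertainty that one case gives. Compound 4 is estimated at 850 nM in this assay, with a likely range from 350 nM to 2200 nM.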

Compound 4, half-maximal inhibitory concentration: 201 nM
Estimate against measurement, compound 4: 4.2-fold (0.63 log units) above, outside the stated range (below it).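

In this assay, methoxy in place of chloro on the core of compound 3 gave a 1.6-fold lower number from compound 3 to compound 4 (0.20 log units; within the scatter), so 3-chlorophenyl and 3-methoxyphenyl cannot be told apart on this core. Set beside the earlier step, the change did not carry over in the same way from one core to the other: the same change on two cores in this assay, a 2.8-fold higher number (0.45 log units; beyond the scatter) from compound 1 to compound 2 and a 1.6-fold lower number (0.20 log units; within the scatter) from compound 3 to compound 4, 4.4-fold (0.64 log units) apart, beyond the scatter of two such steps. This shows that the weakening seen on the core of compound 1 cannot be taken as a general result of this change in the series, but two pairs do not show which feature of the two cores sets the outcomes apart.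

The compounds shown carry only chloro and methoxy at this place, so it remains open how a group such as an amine, a nitrile or a carboxylic acid would behave there on either core. As far as these compounds go, it also remains open which outcome the same change would follow on a third core, for example one bearing a longer chain such as propyl.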